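The compounds below may be only part of what the source reports. "The series", "measured", "known", "first", "only" and "open" are said of these compounds alone.

Series notes. Compound 1 `COC(=O)C1=C(C)N=C(SC)NC1c1cccc([N+](=O)[O-])c1SC` gives 30 nM in an assay on Myocardium (Cavia porcellus) for displacement of a labelled ligand from Voltage-dependent L-type calcium channel subunit alpha-1C (Homo sapiens); a higher number here means weaker binding, a lower number tighter binding. Compound 2 `CSC1=NC(c2cccc([N+](=O)[O-])c2)C2=C(O)OCC2=N1` gives 36900 nM in this assay, and compound 3 `CSC1=NC(c2ccccc2SC)C2=C(O)OCC2=N1` gives 45200 nM. Compound 3 stands at the highest of the three numbers: its value and that of compound 2 lie within the scatter of each other, while the gap from compound 3 to compound 1 is far beyond it. Compound 1 and compound 3 differ in more than one place, so nothing is read from that pair alone.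

Compound 4 `CSC1=NC(c2cccc([N+](=O)[O-])c2SC)C2=C(O)OCC2=N1` differs from compound 3 by nitro in place of hydrogen on an aromatic carbon. Going by the values given here, no single-change step among the measured compounds covers this change. With a core like that of compound 3 and nitro alone on the ring, compound 2 still gives 36900 nM, which argues against a large move. Among the compounds with values here, both groups together on the ring are seen only in compound 1, with its own core. A modest tightening is expected, a 4.5-fold lower number from compound 3 to compound 4 (0.66 log units; beyond the scatter). Compound 4 is estimated at 10000 nM, within 2000 nM to 40000 nM.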

Compound 4, dissociation constant: 13700 nM
For compound 4 the middle estimate is 1.4-fold (0.14 log units) below the measured one; measured number inside the range.
By their numbers in this assay, from the lowest: compound 1; then compound 4; then compounds 2 and 3 (each within the scatter of the next).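

In this assay the step of a 3.3-fold lower number from compound 3 to compound 4 (0.52 log units; beyond the scatter) shows that nitro on an aromatic carbon ortho to a methylsulfanyl group does move the number on this core, and the step of a 2.7-fold lower number from compound 2 to compound 4 (0.43 log units; beyond the scatter) shows the same for adding the methylsulfanyl group to the ring. Both steps are modest, so on this core each ring group adds only a small tightening to the other. Nothing given here bears on the cause of these steps.

From the compounds shown here alone, whether an amine or a carboxylic acid at the nitro position, or a longer chain in place of methylsulfanyl, would move the number further stays open. Going by these compounds, how each ring group acts alone on the core of compound 1 also stays open, as that core appears here only with both groups present.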